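Hydrazone aryl variation on the urea-linked triazolylpyridine series

The source may report more compounds than this note shows. Statements on the series, on what has been measured and on what is new or still open speak of the compounds shown alone.

Measured so far in a functional assay on U-87MG ATCC cells (Homo sapiens) for cytotoxicity, read by MTT assay, with a stated time of 72 h; on this read-out lower numbers stand for stronger inhibition and higher numbers for weaker inhibition:
compound 1 `COc1ccc(OC)c(/C=N/NC(=O)Nc2ccc(Oc3ccnc(-c4nncn4CCN(C)C)c3)c(F)c2)c1`: 6400 nM
compound 2 `CN(C)CCn1cnnc1-c1cc(Oc2ccc(NC(=O)N/N=C/c3ccc(Cl)cc3)cc2F)ccn1`: 1370 nM
compound 3 `CN(C)CCn1cnnc1-c1cc(Oc2ccc(NC(=O)N/N=C/c3cc(Br)c(O)c(Br)c3)cc2F)ccn1`: > 100000 nM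

Compound 1 stands highest of the two numbers available; the nearest is compound 2, reached by a 4.7-fold lower number from compound 1 to compound 2 (0.67 log units; beyond the scatter). The value of compound 3 is a limit of this assay, not a number (the limit of > 100000 nM in this assay, at which 1 of the 3 values shown sits).

Compound 4 `CN(C)CCn1cnnc1-c1cc(Oc2ccc(NC(=O)N/N=C/c3c(O)ccc4ccccc34)cc2F)ccn1` is not yet measured. It differs from compound 1 in one place (2-hydroxynaphthalen-1-yl in place of 2,5-dimethoxyphenyl on a carbon with a double bond to nitrogen).

Two of the measured steps bear on this change, as both alter the aryl group on the carbon with a double bond to nitrogen. Both steps that end in 3,5-dibromo-4-hydroxyphenyl were large and ran toward weaker inhibition: an at least 15-fold higher number from compound 1 to compound 3 (1.19 log units; beyond the scatter) and an at least 72-fold higher number from compound 2 to compound 3 (1.86 log units; beyond the scatter). The step to 4-chlorophenyl, a 4.7-fold lower number from compound 1 to compound 2 (0.67 log units; beyond the scatter), ran the other way and was only modest. Among the measured compounds shown here, no measured step involves a bicyclic aryl group, so the direction for 2-hydroxynaphthalen-1-yl is uncertain; the nearest precedent points toward a higher number.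

Compound 4 is therefore estimated to give about 12000 nM, expected to lie between 2500 nM and 60000 nM. That estimate means a 1.9-fold higher number from compound 1 to compound 4 (0.27 log units; within the scatter).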

Compound 4, half-maximal inhibitory concentration: 620 nM
Compound 4: middle estimate off by 19-fold (1.29 log units), on the high side, outside the stated range (below it).
By their numbers in this assay, from the lowest: compound 4; then compound 2; then compound 1. At a limit, above all of these: compound 3.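

Working notes on the aryl group on the carbon with a double bond to nitrogen: in this assay, this place tolerates a second aromatic ring, since 2-hydroxynaphthalen-1-yl gives a 10-fold lower number from compound 1 to compound 4 (1.01 log units; beyond the scatter) and also a 2.2-fold lower number from compound 2 to compound 4 (0.34 log units; beyond the scatter) against the best monocyclic aryl group shown, which leaves compound 4 with the lowest number of the four. A hydroxyl on the aryl group does not by itself go with weak inhibition, since compound 3 and compound 4 both carry one and the series shows an at least 160-fold lower number from compound 3 to compound 4 (2.20 log units; beyond the scatter) between them. The value of compound 3 is a limit and not a number: the limit of > 100000 nM in this assay, at which 1 of the 4 values shown sits.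

The second ring and the hydroxyl enter together in compound 4, and dimethoxy groups leave at the same time, so the compounds shown leave open which of these changes carries the step. An unsubstituted naphthalen-1-yl group, a 2-methoxynaphthalen-1-yl group or a 2-aminonaphthalen-1-yl group would separate these parts, and a 2-hydroxyphenyl group would show whether the hydroxyl holds up without the second ring.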